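The compounds below may be only part of what the source reports. "The series", "measured", "known", "first", "only" and "open" are said of these compounds alone.

Measured so far:
- compound 1 `CCN(CC)c1nc(C)nc2c(-c3c(C)cc(OC)cc3OC)c(C)nn12`: 1.2 nM
- compound 2 `CCN(CC)c1nc(C)nc2c(-c3cc(OC)c(OC)cc3Br)c(C)nn12`: 4.06 nM
- compound 3 `CCCCN(CC)c1nc(C)nc2c(-c3c(C)cc(OC)cc3C)c(C)nn12`: 4.22 nM

All three were tested in an assay on cell membranes for displacement of a labelled ligand from corticotropin-releasing factor receptor 1 (Rattus norvegicus); a lower number here means a stronger inhibitor, a higher number a weaker inhibitor. Compound 1 gives the lowest number of the three; compound 2 and compound 3 each give a higher number, and both of those gaps are beyond the usual scatter, so compound 1 is the strongest inhibitor of the three in this assay. Compound 2 and compound 3 differ from compound 1 in several places at once, so their values say nothing about any single change.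

Compound 4 `CCCN(c1nc(C)nc2c(-c3c(C)cc(OC)cc3OC)c(C)nn12)C1CC1` keeps the core and the aromatic ring of compound 1 and changes only the amine on the core: cyclopropyl(propyl)amino in place of diethylamino on an aromatic carbon. Within the data shown here, no pair of measured compounds shows this change on its own, so its effect in this assay has to be estimated. Since compound 1 already gives 1.2 nM and the rest of the molecule is unchanged, a small step is expected, most likely toward a somewhat higher number, and possibly none beyond the scatter. Compound 4 is therefore expected to give about 2.2 nM, within a range of 0.6 nM to 8 nM. The expected step of a 1.8-fold higher number from compound 1 to compound 4 (0.26 log units; within the scatter) is modest.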

Compound 4, half-maximal inhibitory concentration: 1.48 nM
Compound 4: the middle estimate sits 1.5-fold (0.17 log units) above what was measured; measured number inside the range.
By their numbers in this assay, from the lowest: compounds 1 and 4 (each within the scatter of the next); then compounds 2 and 3 (each within the scatter of the next).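

In this assay, among these compounds, the step for cyclopropyl(propyl)amino in place of diethylamino is a 1.2-fold higher number from compound 1 to compound 4 (0.09 log units; within the scatter), the first comparison here in which only one place differs. The group on this aromatic carbon, between two ring nitrogen atoms, can therefore grow from 5 heavy atoms to 7 and gain a three-membered ring without a shift beyond the scatter, at least with the aromatic ring of compound 1 in place. Nothing measured here accounts for this result.

Going by these compounds, this single swap covers only two amines, both with two carbon substituents on the nitrogen, so it remains open how the assay would respond to a pyrrolidine or morpholine ring that includes the nitrogen, to a methoxyethyl chain, or to an amine keeping a hydrogen on the nitrogen, such as propylamino. On these data alone, it is also open whether cyclopropyl(propyl)amino would behave the same way alongside the different aromatic ring of compound 2, which differs from compound 4 in more than one place.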